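The source may report more compounds than this note shows. Statements on the series, on what has been measured and on what is new or still open speak of the compounds shown alone.

Compound 1, `COc1cc(/C=N/NC(=O)CCCc2nc3ccccc3c(=O)[nH]2)ccc1O`, gives 115000000 nM in a physicochemical assay, read by spectrophotometry, with a stated time of 6 min; a higher number here means a weaker inhibitor, a lower number a stronger inhibitor.
Compound 2, `COc1ccc(/C=N/NC(=O)CCCc2nc3ccccc3c(=O)[nH]2)cc1`, gives 180000000 nM in this assay.
Compound 3, `COc1cc(/C=N/NC(=O)CCc2nc3ccccc3c(=O)[nH]2)ccc1O`, gives 95000000 nM in this assay.

The three measured compounds share a hydrazone linked to a quinazolinone-bearing chain, and all three sit at very weak inhibition in this assay. Compound 1 and compound 2 differ in one place: 4-methoxyphenyl in place of 4-hydroxy-3-methoxyphenyl on a carbon with a double bond to nitrogen. That change made a step of a 1.6-fold higher number from compound 1 to compound 2 (0.19 log units; within the scatter), which lies within the scatter of repeated measurements, so the two compounds cannot be told apart by this assay. Compound 3 carries the same aryl group as compound 1 on a shorter chain; the difference between the two cores is not broken down here. Its value falls within the scatter of both compound 1 and compound 2.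

Compound 4, `COc1ccc(/C=N/NC(=O)CCc2nc3ccccc3c(=O)[nH]2)cc1`, has not yet been measured in this assay. It differs from compound 3 in the same way that compound 2 differs from compound 1: 4-methoxyphenyl in place of 4-hydroxy-3-methoxyphenyl on a carbon with a double bond to nitrogen. The surroundings of the change are the same in both pairs, so it is the same change made on the shorter-chain core.

Because the earlier step of a 1.6-fold higher number from compound 1 to compound 2 (0.19 log units; within the scatter) was within the scatter, the step from compound 3 to compound 4 is expected to be small as well, about a 1.6-fold higher number from compound 3 to compound 4 (0.20 log units; within the scatter). Compound 4 is therefore estimated at 150000000 nM, with a likely range from 75000000 nM to 300000000 nM, which would leave it among the other three as a very weak inhibitor.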

Compound 4, half-maximal inhibitory concentration: 75000000 nM
For compound 4 the middle estimate is 2.0-fold (0.30 log units) above the measured one, and the stated range covers the measured number.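

In this assay, the new step is a 1.3-fold lower number from compound 3 to compound 4 (0.10 log units; within the scatter), and the matching step on the other core is a 1.6-fold higher number from compound 1 to compound 2 (0.19 log units; within the scatter). Putting 4-methoxyphenyl in place of 4-hydroxy-3-methoxyphenyl therefore gave no difference that this assay can read on either core, and in that limited sense the outcome carried from one core to the other. This does not show that the change has a real effect of shared size or direction, or that it would remain this small on any further core, and no measurement shown here offers an explanation for the result.

The compounds shown cover only these two aryl groups and two chain lengths, all of them very weak inhibitors, so they cannot show which parts of the structure, if any, control the number in this assay. On these data alone, it remains open whether an aryl group carrying an amine or a carboxylic acid, or a longer chain on the shared core, would give a step beyond the scatter, and whether the exchange of aryl groups would stay unreadable in such compounds.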